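A few compounds are considered here, and "the series" means these few. Any claim that something is new, unique, unknown or untested is made for them only; others in the source may bear on it.

The study brings together two compounds of one shared core and a further compound that has not yet been measured. Compound 1, `O=c1[nH]c2ncc(Br)nc2n1C1CCCCC1`, in an ADME assay on microsomes from liver (Homo sapiens), read by LC-MS, with a stated time of 90 min (a lower number here means that the liver removes a smaller share, a higher number that the liver removes a larger share of the compound in one pass), has the entry "not determined" (no result reported). Compound 2, `CCC(CC)n1c(=O)[nH]c2ncc(C)nc21`, is the starting point of the step followed here. In this assay compound 2 gives < 0.2, which is a limit of the assay rather than a number. Where compound 2 stands is thus told only by the limit of < 0.2 in this assay, at which 1 of the 2 values shown sits, and no step between two measured compounds exists to set the scale of change. Compound 3, `CCC(CC)n1c(=O)[nH]c2ncc(OC)nc21`, differs from compound 2 in one place: methoxy in place of methyl on an aromatic carbon. With nothing measured to lean on, the account expects a step a number at least 0.10 higher from compound 2 to compound 3 (that floor lies within the scatter), estimated to run upward and to be of a size near the usual scatter rather than well beyond it. For compound 3 in this assay the expected value is 0.3, with a range from 0.1 to 0.55, and the measurement itself is awaited.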

Compound 3, hepatic extraction ratio: < 0.2
Compound 3 gave a limit, no number; the forecaster's own chance of this, stated with the estimate: 30%; middle value at least 0.10 from the limit.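

In this assay, for the compounds shown here, compound 2 and compound 3 both rest on a limit of the assay rather than a number, and no step between them can be read: the limit of < 0.2 in this assay, at which 2 of the 3 values shown sit. The compounds shown leave open where the actual values of compound 2 and compound 3 lie, and whether methoxy in place of methyl on an aromatic carbon changes anything here.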